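Swapping the Ring on the Carbonyl: An Expected Cytotoxicity Read-out

A few compounds are considered here, and "the series" means these few. Any claim that something is new, unique, unknown or untested is made for them only; others in the source may bear on it.

Compound 1 `COc1cc(-c2cc(/C=C/C(=O)c3ccc(N)cc3)[nH]n2)cc(OC)c1OC`: 106%
Compound 2 `COc1cc(-c2cc(/C=C/C(=O)c3ccc(Cl)c(Cl)c3)[nH]n2)cc(OC)c1OC`: 94%
Compound 3 `COc1ccc(C(=O)/C=C/c2cc(-c3cc(OC)c(OC)c(OC)c3)n[nH]2)cc1`: 92%

All three compounds share one core and differ only in the ring carried on the carbonyl carbon. They were tested in a functional assay on SK-MEL-2 cells (Homo sapiens) for cytotoxicity, read by sulforhodamine B assay, with a stated time of 48 h, tested at 0.01 uM; on this read-out lower numbers stand for a stronger effect and higher numbers for a weaker effect at the one concentration tested. On these numbers compound 3 stands lowest of the three: a number 2 percentage points lower from compound 2 to compound 3 (within the scatter) lies within the scatter, so compound 2 and compound 3 cannot be told apart, whereas a number 14 percentage points lower from compound 1 to compound 3 (beyond the scatter) lies beyond it, and so does a number 12 percentage points lower from compound 1 to compound 2 (beyond the scatter).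

Compound 4 `COc1cc(-c2cc(/C=C/C(=O)c3ccc(F)c(F)c3)[nH]n2)cc(OC)c1OC` has not yet been measured in this assay. It differs from compound 3 in one place: 3,4-difluorophenyl in place of 4-methoxyphenyl on a carbonyl carbon. Going by the values given here, two measured steps bear on this. a number 2 percentage points lower from compound 2 to compound 3 (within the scatter) exchanged one ring on the carbonyl carbon for another and stayed within the scatter. a number 12 percentage points lower from compound 1 to compound 2 (beyond the scatter) changed that same ring and gave a modest move. The present change again replaces the ring on the carbonyl carbon with one bearing two halogens, as in compound 2, and the measured exchange between compound 2 and compound 3 showed no difference beyond the scatter. The step expected is therefore a number 2 percentage points higher from compound 3 to compound 4 (within the scatter), with no change beyond the scatter anticipated. Compound 4 is estimated at 94%, within a range from 82% to 106%.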

Compound 4, a percentage reported as activity, at one concentration (the size of the read-out at that concentration, not a potency): 93%
Compound 4: the middle estimate sits 1 percentage points above what was measured, and the stated range covers the measured number.
By their numbers in this assay, from the lowest: compounds 3, 4 and 2 (each within the scatter of the next); then compound 1.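

Within this assay, the new result shows that two kinds of exchange at the carbonyl carbon cannot be told apart: replacing 3,4-dichlorophenyl with 3,4-difluorophenyl gives a number 1 percentage points lower from compound 2 to compound 4 (within the scatter), and replacing 4-methoxyphenyl with 3,4-difluorophenyl gives a number 1 percentage points higher from compound 3 to compound 4 (within the scatter). The second exchange removes a ring with a hydrogen-bond acceptor and brings in one with none, yet the read-out does not separate them, so three different rings now form a single group in this assay. The 4-aminophenyl ring remains the one apart, now against all three of those rings, with a number 13 percentage points lower from compound 1 to compound 4 (beyond the scatter), and no supporting measurement is available to explain this or the two exchanges above.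

From the compounds shown here alone, all of these numbers come from the one concentration tested, so it remains open whether the rings in this group would separate under other test conditions. Also open, going by these compounds, is how the position would respond to a ring carrying a carboxylic acid or a nitrile, or to a saturated cyclohexyl ring on the carbonyl carbon.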